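This account rests on a few compounds, and the source may have more. Where it says the series, first, only, none or still open, it means among the compounds named here.

Of the compounds shown here, three built on one shared core have been tested in a functional assay on NCI-H460 cells (Homo sapiens) for antiproliferative activity, read by MTT assay, with a stated time of 48 h; a higher number here means a weaker inhibitor, a lower number a stronger inhibitor. Compound 2 `COc1cc(-c2cccc3nc(-c4cccc(Br)c4)oc23)cc(OC)c1OC` is the only one of them to return a number: in this assay compound 2 gives 3800 nM. Compound 1 `COc1ccc(-c2nc3cccc(-c4cc(OC)c(OC)c(OC)c4)c3o2)cc1OC` reaches only a limit of the assay, giving > 25000 nM in this assay. Compound 3 `COc1cc(-c2cccc3nc(-c4ccc(Cl)cc4)oc23)cc(OC)c1OC` likewise stops at a limit, giving > 25000 nM in this assay. Thus compound 2 stands alone as the sole measured value, and the steps around it are all read against a limit: an at least 6.5-fold lower number from compound 1 to compound 2 (0.81 log units; beyond the scatter), an at least 6.5-fold higher number from compound 2 to compound 3 (0.81 log units; beyond the scatter), while a step that the two limits leave unreadable from compound 1 to compound 3.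

Compound 4 `COc1cc(-c2cccc3nc(-c4cccc(N)c4)oc23)cc(OC)c1OC` has not yet been measured. It differs from compound 2 by amino in place of bromo on an aromatic carbon. Going by the values given here, no measured step exchanges the bromo for an amino, so the nearest guidance comes from the two steps that replace the group on the same aryl ring, an at least 6.5-fold lower number from compound 1 to compound 2 (0.81 log units; beyond the scatter) and an at least 6.5-fold higher number from compound 2 to compound 3 (0.81 log units; beyond the scatter), each of which moved the number beyond the scatter and away from compound 2, and from the limit of > 25000 nM in this assay, at which 2 of the 3 values shown sit. A weakening step in this assay is therefore the more likely outcome, with a real chance that only a limit is returned. Compound 4 is expected to give about 12000 nM, within 3000 nM to 40000 nM. The expected step is a 3.2-fold higher number from compound 2 to compound 4 (0.50 log units; beyond the scatter).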

Compound 4, half-maximal inhibitory concentration: 2600 nM
The estimate for compound 4 lay 4.6-fold (0.66 log units) above the measured number, outside the stated range (below it).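

In this assay, 3-aminophenyl in place of 3-bromophenyl gives a 1.5-fold lower number from compound 2 to compound 4 (0.16 log units; within the scatter), so at this place a measured number does not depend on the bromo, and amino serves as well within the scatter. The two further steps, an at least 9.6-fold lower number from compound 3 to compound 4 (0.98 log units; beyond the scatter) and an at least 9.6-fold lower number from compound 1 to compound 4 (0.98 log units; beyond the scatter), show that the gap first seen with 3-bromophenyl recurs with a second, different group, which sets both 3-substituted rings apart from 4-chlorophenyl and 3,4-dimethoxyphenyl. Among the compounds shown, numbers therefore belong only to those two rings, and the remaining compounds still stop at a limit: the limit of > 25000 nM in this assay, at which 2 of the 4 values shown sit.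

As far as these compounds go, what stays open is whether the place of the group on the ring or the group itself separates the measured compounds from the others, a question that a 4-aminophenyl or a 4-bromophenyl ring would address. From the compounds shown here alone, it is also open whether a hydroxyl or an acetamido group at the same place would stay level with amino and bromo or move the number beyond the scatter.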